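Compound 1 to compound 4: replacing 4-methylphenyl

The source may hold more compounds than are shown below. What is called first, only, known or untested is meant among the compounds shown, and "the series" means these compounds.

Measured so far in an ADME assay on NIH3T3 cells (Mus musculus) for inhibition, read by MTT assay, with a stated time of 48 h; a higher number here means a weaker inhibitor, a lower number a stronger inhibitor:
- Compound 1 `Cc1ccc(-c2nc3ccccn3c2Sc2ccccc2)cc1` gives > 100000 nM as a limit
- Compound 2 `c1ccc(Sc2c(-c3cccc4ccccc34)nc3ccccn23)cc1` gives > 100000 nM as a limit
- Compound 3 `Cc1ccc(-c2nc3ccc(C)cn3c2Sc2ccccc2)cc1` gives > 100000 nM as a limit

Compound 1 stands at the limit of the assay, with no number behind it. The measured set offers a single reading, namely the limit of > 100000 nM in this assay, at which 3 of the 3 values shown sit, and nothing finer.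

Compound 4 `c1ccc(Sc2c(-c3ccsc3)nc3ccccn23)cc1` carries thiophen-3-yl in place of 4-methylphenyl on an aromatic carbon, next to the ring atom that bears a phenylsulfanyl group. The count for this change is thiophen-3-yl in place of 4-methylphenyl on an aromatic carbon in full.

Going by the values given here, the only step between measured compounds is a step that the two limits leave unreadable from compound 1 to compound 3 and it gives no size to carry over. It is also a different change, methyl in place of hydrogen on an aromatic carbon. Because of the limit of > 100000 nM in this assay, at which 3 of the 3 values shown sit, for compound 1 and the two others, no step beyond the scatter is expected in this assay and no direction can be given. The expected step is a number no higher from compound 1 to compound 4 (the limit leaves the size open) and a further limit is the likeliest report. Compound 4 is estimated at 100000 nM with an expected range from 40000 nM to 200000 nM as the working figure.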

Compound 4, half-maximal inhibitory concentration: 94100 nM
Estimate against measurement, compound 4: 1.1-fold (0.03 log units) above; measured number inside the range.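

In this assay, going by these compounds alone, compound 4, with thiophen-3-yl on this aromatic carbon, gives 94100 nM, the first value that is a number and not a limit. Within the data shown here, replacing 4-methylphenyl here gives an at least 1.0-fold lower number from compound 1 to compound 4 (0.02 log units; that floor lies within the scatter), so the change shows no effect beyond the scatter, and its true size stays open, while the one earlier step cannot be read at all. Among these compounds, compound 1, compound 2 and compound 3 remain limits, which leaves the single number of compound 4 with no other number to be set against: the limit of > 100000 nM in this assay, at which 3 of the 4 values shown sit.

All the groups shown on this aromatic carbon are aromatic rings without a charge, so it remains open whether an aminomethyl or carboxylic acid substituent on such a ring would bring the number in this assay well away from the limit. Also open is what a change to the phenylsulfanyl group would do, for example a morpholine or a longer chain in its place, since every compound shown carries that group unchanged.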